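This account rests on a few compounds, and the source may have more. Where it says the series, first, only, none or still open, it means among the compounds named here.

Measured compounds:
compound 1 `CC1(C)[C@H]2CC[C@]1(C)N(Cc1cn(-c3ccc(O)cc3)nn1)C(=O)C2`, 100 nM
compound 2 `Cc1ccc(-n2cc(CN3C(=O)C[C@@H]4CC[C@@]3(C)C4(C)C)nn2)cc1`, 270 nM

Compound 1 carries a 4-hydroxyphenyl group on the shared core, and in a functional assay on PANC-1 cells (Homo sapiens) for inhibition, read by MTT assay, with a stated time of 24 h (a lower number here means a stronger inhibitor, a higher number a weaker inhibitor), compound 1 gives 100 nM, the lowest of the two numbers measured. Compound 2, where a methyl group has taken the place of that hydroxy group, gives 270 nM in this assay; the step of a 2.7-fold higher number from compound 1 to compound 2 (0.43 log units; beyond the scatter) is modest but beyond the scatter.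

Compound 3 `COc1ccc(-n2cc(CN3C(=O)C[C@@H]4CC[C@@]3(C)C4(C)C)nn2)cc1` has not yet been measured. It differs from compound 1 by methyl in place of hydrogen on an oxygen on an aromatic ring, so the hydroxy becomes a methoxy on the same ring. For the measured compounds named here, the only measured step that bears on this change is the one from hydroxy to methyl, a 2.7-fold higher number from compound 1 to compound 2 (0.43 log units; beyond the scatter), which removed the hydrogen-bond donor of compound 1 and raised the number. Replacing the hydroxy hydrogen with methyl likewise removes that donor, so a step of similar size and direction is expected. Compound 3 is therefore estimated to give 220 nM in this assay, within a range from 90 nM to 550 nM, corresponding to an expected step of a 2.2-fold higher number from compound 1 to compound 3 (0.34 log units; beyond the scatter).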

Compound 3, half-maximal inhibitory concentration: 330 nM
The estimate for compound 3 lay 1.5-fold (0.18 log units) below the measured number, within the range that was stated.
By their numbers in this assay, from the lowest: compound 1; then compounds 2 and 3 (each within the scatter of the next).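

In this assay, a methyl placed on the oxygen of the 4-hydroxyphenyl group gives a 3.3-fold higher number from compound 1 to compound 3 (0.52 log units; beyond the scatter), so the number moves away from that of compound 1 even when the oxygen stays in place, a case the earlier pair could not address. The further comparison gives a 1.2-fold higher number from compound 2 to compound 3 (0.09 log units; within the scatter), so methoxy and methyl on this aromatic carbon cannot be told apart here, and compound 1, the only one of the three with the hydroxy group, remains the strongest inhibitor among them. Nothing at hand explains why the hydroxy compound stands apart from the other two.

The compounds shown leave open whether the hydroxy group is unusual at this place on the ring, or whether an amine, a carboxylic acid or a fluorine there would give a number close to that of compound 1 rather than those of compound 2 and compound 3. They also leave open whether a longer chain on the oxygen, such as ethoxy, would stay level with compound 3 or move further from compound 1.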